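Solubility notes on two measured analogues and one pending

The compounds below may be only part of what the source reports. "The series", "measured", "known", "first", "only" and "open" are said of these compounds alone.

compound 1 `COc1ccc(-c2cc(-c3ccc(NS(C)(=O)=O)cc3)cnc2N)cn1`: > 100 ug/mL in a physicochemical assay for solubility, read by nephelometry, measured as kinetic solubility, at pH 2; on this read-out higher numbers stand for higher solubility and lower numbers for lower solubility
compound 2 `COc1ccc(-c2cc(-c3ccc(S(C)(=O)=O)c(F)c3)cnc2N)cn1`: > 100 ug/mL in this assay

Both readings are limits of the assay rather than numbers. Compound 1 sits at the limit (the limit of > 100 ug/mL in this assay, at which 2 of the 2 values shown sit), which is also where compound 2 sits, so the numbers shown do not separate the two. Among the compounds with values here, no step between measured compounds that differ in one place is available, and the position of compound 1 is known only as a limit.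

Compound 3 `COc1ccc(-c2cc(-c3ccc(C(=O)N(C)C)cc3)cnc2N)cn1` differs from compound 1 in one place: dimethylcarbamoyl in place of methanesulfonamido on an aromatic carbon. The group that leaves and the group that enters are of the same heavy-atom count, and the ring and the rest of the shared core are untouched.

With both measured values resting at the limit, the step from compound 1 to compound 3 in this assay is expected to be none beyond the scatter, estimated as a number no higher from compound 1 to compound 3 (the limit leaves the size open). Compound 3 is accordingly expected to give about 100 ug/mL in this assay, within a range of 30 ug/mL to 200 ug/mL, with a fair chance that the read-out is again reported only as a limit.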

Compound 3, solubility: > 100 ug/mL
Compound 3 was reported as a limit; the forecaster's own chance of this, stated with the estimate: 60%; the middle value lies on the limit itself.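

Compound 3 gives > 100 ug/mL in this assay as a limit of the assay, not a number. No step can be read from compound 1 to compound 3, and the readings do not separate the compounds shown: the limit of > 100 ug/mL in this assay, at which 3 of the 3 values shown sit.
Still open, going by these compounds, is how soluble each compound is past that limit, and whether dimethylcarbamoyl in place of methanesulfonamido on an aromatic carbon shifts the read-out at all.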